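Swapping the Bicyclic Amide for a Fluorophenyl Amide

The source may hold more compounds than are shown below. What is called first, only, known or untested is meant among the compounds shown, and "the series" means these compounds.

Measured so far:
Compound 1 `CO[C@H]1CC[C@H](NC(=O)c2n[nH]cc2NC(=O)c2cnc3ccccn23)CC1`: 5900 nM
Compound 2 `CO[C@H]1CC[C@H](NC(=O)c2n[nH]cc2NC(=O)c2c(C)nc3ccccn23)CC1`: 34000 nM
Compound 3 `COc1cccc(OC)c1C(=O)Nc1c[nH]nc1C(=O)Nc1ccccc1`: a limit, > 50000 nM

In an ADME assay on MRC5 cells (Homo sapiens) for inhibition, with a stated time of 72 h (on this read-out lower numbers stand for an effect already at smaller amounts and higher numbers for an effect only at larger amounts of compound), compound 1 gives the lowest of the two numbers; compound 2 lies a 5.8-fold higher number from compound 1 to compound 2 (0.76 log units; beyond the scatter) away. The value of compound 3 is a limit of the assay, not a number. Compound 4 `CO[C@H]1CC[C@H](NC(=O)c2n[nH]cc2NC(=O)c2ccccc2F)CC1` differs from compound 1 by a group of 7 heavy atoms (6 carbon, 1 fluorine; one six-membered aromatic ring of carbon only) in place of a group of 9 heavy atoms (7 carbon, 2 nitrogen; one five-membered aromatic ring with 2 hetero atoms, one six-membered aromatic ring with 1 hetero atom), on a carbonyl carbon. Among the measured compounds shown here, no measured step tests this change: the only measured step, a 5.8-fold higher number from compound 1 to compound 2 (0.76 log units; beyond the scatter), concerns a methyl on an aromatic carbon, a different place. The 2-fluorophenyl amide removes two hydrogen-bond acceptors, and compound 3 shows that an aryl amide variant can sit at the limit (the limit of > 50000 nM in this assay, at which 1 of the 3 values shown sits). An estimated worsening, a 2.5-fold higher number from compound 1 to compound 4 (0.41 log units; beyond the scatter), is expected; compound 4 is expected near 15000 nM, between 4000 nM and 50000 nM.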

Compound 4, half-maximal effective concentration: 1000 nM
Compound 4: the middle estimate sits 15-fold (1.18 log units) above what was measured, and the stated range ends above it.
By their numbers in this assay, from the lowest: compound 4; then compound 1; then compound 2. At a limit, above all of these: compound 3.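

On this carbonyl carbon, the whole group with its two nitrogen-bearing aromatic rings can give way to 2-fluorophenyl, and in this assay the change gives a 5.9-fold lower number from compound 1 to compound 4 (0.77 log units; beyond the scatter). The earlier step covered only a methyl on an aromatic carbon, whereas this one shows that the hydrogen-bond acceptors of the departing group are not needed for an effect at smaller amounts of compound. Nothing shown explains the shift. Going by these compounds, whether the fluorine itself matters remains open: a plain phenyl or a 2-chlorophenyl group on this carbonyl carbon would test that.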